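The source may report more compounds than this note shows. Statements on the series, on what has been measured and on what is new or still open speak of the compounds shown alone.

Compound 1 `O=C(CN(c1nc(Cl)nc2[nH]cnc12)C1CC1)N[C@@H](CO)C(=O)OCc1ccccc1` is the starting point of this comparison. In a functional assay on the whole organism (Tail, strain ICR) with Mus musculus as the target, in the tail flick test, with a stated time of 150 min, at a dose of 25 umol/kg by the oral route (on this read-out higher numbers stand for a stronger effect at the one dose given and lower numbers for a weaker effect), compound 1 gives 27.9%, the highest of the three measured numbers. Compound 2 `NC(=O)CC[C@H](NC(=O)CN(c1ncnc2c1ncn2C1CCCCO1)C1CC1)C(=O)OCc1ccccc1` gives 10.7% in this assay, and compound 3 `O=C(CN(c1ncnc2c1ncn2C1CCCCO1)C1CC1)NCC(=O)OCc1ccccc1` gives 7.26%, both lying beyond the scatter below compound 1. Compound 4 `N=C(N)NCCC[C@H](NC(=O)CN(c1nc(Cl)nc2[nH]cnc12)C1CC1)C(=O)OCc1ccccc1` has not been measured yet; it differs from compound 1 by a group of 6 heavy atoms (3 carbon, 3 nitrogen; no ring) in place of one oxygen atom, on a saturated chain carbon, two bonds along the chain from an amide-type nitrogen and a carbonyl carbon. For the measured compounds named here, the only measured step that alters a side chain at a comparable place is a number 3.4 percentage points lower from compound 2 to compound 3 (within the scatter), a change made on a different core from that of compound 1, where removing a side chain barely moved the read-out. Going by the values given here, that step is the sole guide available, and it gives no sign of a shift beyond the scatter in this assay. Compound 4 is therefore expected to land close to compound 1. The expected step is a number 2.9 percentage points lower from compound 1 to compound 4 (within the scatter). The estimated value for compound 4 in this assay is 25%, with a range from 10% to 40%.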

Compound 4, a percentage reported as activity, at one dose (the size of the read-out at that dose, not a potency): 6.12%
Compound 4: middle estimate off by 18.9 percentage points, on the high side, outside the stated range (below it).
By their numbers in this assay, from the lowest: compounds 4, 3 and 2 (each within the scatter of the next); then compound 1.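

In this assay, replacing the hydroxy with a group of 6 heavy atoms (3 carbon, 3 nitrogen; no ring) gives a number 21.8 percentage points lower from compound 1 to compound 4 (beyond the scatter), so this saturated chain carbon, two bonds along the chain from an amide-type nitrogen and a carbonyl carbon, is sensitive to what it carries on the core of compound 1. For the compounds shown here, the only earlier side-chain step, a number 3.4 percentage points lower from compound 2 to compound 3 (within the scatter), was made on a different core and gave no sign of this sensitivity. Nothing measured here explains the fall.

The compounds shown leave open whether the loss of the hydroxy or the arrival of the new group matters more. They also leave open how a methyl group, a short chain ending in an amine or a carboxylic acid would fare at this place on the same core.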